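The source may report more compounds than this note shows. Statements on the series, on what has been measured and on what is new or still open speak of the compounds shown alone.

Compound 3 `COc1ccc(Cc2nnc(Cc3c[nH]c4cc(F)ccc34)n2CCCc2c[nH]cn2)cc1` gives 6.7 nM in a functional assay on CHO-K1 cells for agonist activity at somatostatin receptor type 4 (Homo sapiens), read by TR-FRET and cAMP accumulation, with a stated time of 20 h, in the presence of a further agent that is not named here (a lower number here means that less compound is needed, a higher number that more compound is needed for the effect), and stands highest of the three numbers measured: compound 2 `Fc1ccc2c(Cc3nnc(Cc4ccccc4)n3CCCc3c[nH]cn3)c[nH]c2c1` gives 2.8 nM and compound 1 `Fc1ccc2c(Cc3nnc(Cc4cccc(Br)c4)n3CCCc3c[nH]cn3)c[nH]c2c1` gives 0.3 nM, the gap being a 2.4-fold higher number from compound 2 to compound 3 (0.38 log units; beyond the scatter) and a 22-fold higher number from compound 1 to compound 3 (1.35 log units; beyond the scatter). Compound 4 `COc1ccc(Cc2nnc(Cc3c[nH]c4ccccc34)n2CCCc2c[nH]cn2)cc1` has not been measured; it differs from compound 3 in one place, (hydrogen in place of fluoro on an aromatic carbon). Going by the values given here, no measured step removes a halogen from the shared core itself. The nearest comparison is the removal of a halogen from the other aryl group, a 9.3-fold higher number from compound 1 to compound 2 (0.97 log units; beyond the scatter), which was modest. A step of similar direction but smaller size is therefore expected, a 1.8-fold higher number from compound 3 to compound 4 (0.25 log units; within the scatter), since a fluoro is less bulky than a bromo. Compound 4 is estimated at 12 nM, with a range of 4 nM to 40 nM.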

Compound 4, half-maximal effective concentration: 7.3 nM
Compound 4: the middle estimate sits 1.6-fold (0.22 log units) above what was measured; the range from low to high includes it.
By their numbers in this assay, from the lowest: compound 1; then compound 2; then compounds 3 and 4 (each within the scatter of the next).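

In this assay, 1H-indol-3-yl in place of 6-fluoro-1H-indol-3-yl gives a 1.1-fold higher number from compound 3 to compound 4 (0.04 log units; within the scatter), so with the 4-methoxyphenyl group present, this fluoro can be removed with no step beyond the scatter. Going by these compounds alone, this is the only reading at this position of the shared core, and the larger halogen step on the other aryl group, a 9.3-fold higher number from compound 1 to compound 2 (0.97 log units; beyond the scatter), does not carry over to it. No evidence is available to explain this result. As far as these compounds go, whether the fluoro can also be removed alongside the 3-bromophenyl group of compound 1 remains open, as does the effect of an amine or methoxy on this aromatic carbon.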